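The compounds below may be only part of what the source reports. "The series", "measured", "known", "first", "only" and "open" are said of these compounds alone.

Measured in an assay on U2OS cells for activation of nuclear factor erythroid 2-related factor 2 (Homo sapiens), read by beta-arrestin recruitment, with a stated time of 6 h; on this read-out higher numbers stand for an effect only at larger amounts of compound and lower numbers for an effect already at smaller amounts:

compound 1 `O=S(=O)(/C=C/c1ccccn1)c1ccccc1F` gives 1050 nM
compound 2 `O=S(=O)(/C=C/c1ccc(Cl)cn1)c1ccccc1F` gives 1040 nM
compound 3 `O=S(=O)(/C=C/c1ccccn1)c1ccc(F)cc1` gives 3100 nM

Compound 2 differs from compound 1 by chloro in place of hydrogen on an aromatic carbon. On this read-out the change made a 1.0-fold lower number from compound 1 to compound 2 (0.00 log units; within the scatter), so the chloro on the core of compound 1 left the number essentially where it was. Compound 3 is built on another core; the difference between the two cores is not broken down here. Compound 3 stands at the highest number of the three, beyond the scatter above compound 1 and above compound 2.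

Compound 4 `O=S(=O)(/C=C/c1cccc(Cl)n1)c1ccc(F)cc1` has not yet been measured. It differs from compound 3 by chloro in place of hydrogen on an aromatic carbon. For the measured compounds named here, this is the same kind of change as the one from compound 1 to compound 2, not the same: in compound 2 the chloro sits two atoms from the ring nitrogen, para to a large group, whereas in compound 4 it sits next to the ring nitrogen, meta to a large group. Going by the values given here, the only measured chloro step, a 1.0-fold lower number from compound 1 to compound 2 (0.00 log units; within the scatter), was flat, so a step of about a 1.0-fold lower number from compound 3 to compound 4 (0.01 log units; within the scatter) is expected from compound 3 to compound 4, with added room for the different place of the chloro. For compound 4 the expected value in this assay is 3000 nM, estimated to lie between 1300 nM and 7000 nM.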

Compound 4, half-maximal effective concentration: 2790 nM
For compound 4 the middle estimate is 1.1-fold (0.03 log units) above the measured one; low and high end bracket the measured number.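

In this assay chloro in place of hydrogen on an aromatic carbon is again flat on the second core (a 1.1-fold lower number from compound 3 to compound 4 (0.05 log units; within the scatter)), and the two steps agree: the same change on two cores in this assay, a 1.0-fold lower number (0.00 log units; within the scatter) from compound 1 to compound 2 and a 1.1-fold lower number (0.05 log units; within the scatter) from compound 3 to compound 4, 1.1-fold (0.04 log units) apart, within the scatter of two such steps.

Within these two pairs, then, the change carries from one core to the other without moving the number, although the chloro stands at a different place on the ring in each pair. For the compounds shown here, this does not show that the change is neutral across the series: only two pairs exist, core and chloro place vary together so their contributions cannot be separated, and agreement between two flat steps says nothing about whether a step of real size would carry.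

Still open, from the compounds shown here alone, is whether an amine, a carboxylic acid or a nitrile in place of the chloro on the six-membered aromatic ring with 1 nitrogen would move the number beyond the scatter. Also open, going by these compounds, is whether a chloro on the other aromatic ring would stay as flat as it does here.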